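Sulfonamide-amine series: methoxybenzyl variant of compound 1 ahead

This account rests on a few compounds, and the source may have more. Where it says the series, first, only, none or still open, it means among the compounds named here.

Within the data shown here, compound 1 `O=S(=O)(NCCCCNCc1ccc(Br)cc1)c1cc(C(F)(F)F)cc(C(F)(F)F)c1` gives 2100 nM in a functional assay on MIA PaCa-2 cells (Homo sapiens) for inhibition, read by MTT assay, with a stated time of 72 h (a higher number here means a weaker inhibitor of growth, a lower number a stronger inhibitor of growth), the lowest of the three numbers so far. Compound 2 `O=S(=O)(NCCCCCCNCc1ccc(Br)cc1)c1ccc(C(F)(F)F)cc1` gives 3830 nM in this assay, within the scatter of compound 1, so no order between those two can be claimed. Compound 3 `O=S(=O)(NCCCCCCNCc1ccc(Br)cc1)c1c(Cl)cccc1Cl` gives 14700 nM in this assay, a gap from compound 1 that lies beyond the scatter. Compound 4 `COc1ccc(CNCCCNS(=O)(=O)c2cc(C(F)(F)F)cc(C(F)(F)F)c2)cc1` is not yet measured. It differs from compound 1 in one place: (4-methoxybenzyl)amino in place of ((4-bromobenzyl)amino)methyl on a saturated chain carbon, three bonds along the chain from a sulfonamide nitrogen. Among the measured compounds shown here, no pair among the measured compounds isolates this change, so nothing measured bears on it directly. The step from compound 1 to compound 4 is expected to be a 2.0-fold higher number from compound 1 to compound 4 (0.30 log units; within the scatter) in this assay, a weakening at the edge of the scatter. Compound 4 is expected to give 4200 nM, within 1500 nM to 12000 nM.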

Compound 4, concentration for 50% growth inhibition: 2500 nM
Beside the measured number, compound 4's estimate is 1.7-fold (0.23 log units) above it; low and high end bracket the measured number.
By their numbers in this assay, from the lowest: compounds 1, 4 and 2 (each within the scatter of the next); then compound 3.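

Among these compounds, this is the only pair that isolates a change at this place: in this assay, (4-methoxybenzyl)amino in place of ((4-bromobenzyl)amino)methyl on a saturated chain carbon, three bonds along the chain from a sulfonamide nitrogen, gives a 1.2-fold higher number from compound 1 to compound 4 (0.08 log units; within the scatter). The position therefore accepts this exchange without a resolvable change in the number. No measurement on hand offers an explanation for this result.

The step joins a change of ring substituent with a change of chain, and no compound shown separates them. From the compounds shown here alone, an unsubstituted benzylamino group or a (4-carboxybenzyl)amino group at this place remains open.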